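Swapping butylamino for ethyl(methyl)amino

The source may report more compounds than this note shows. Statements on the series, on what has been measured and on what is new or still open speak of the compounds shown alone.

Going by the values given here, in a functional assay on the whole organism with Rattus norvegicus as the target (on this read-out higher numbers stand for an effect only at larger amounts of compound and lower numbers for an effect already at smaller amounts), compound 2 `CCCCNc1cccc(NC(=O)C(=O)OCC)c1C#N` gives 0.3 mg/kg, the lowest of the two numbers so far, while compound 1 `CCOC(=O)C(=O)Nc1cccc(N(C)C)c1C#N` gives 4.2 mg/kg. Compound 3 `CCOC(=O)C(=O)Nc1cccc(N(C)CC)c1C#N` carries ethyl(methyl)amino in place of butylamino on an aromatic carbon. Among the compounds with values here, the one measured step that bears on this is the large 14-fold lower number from compound 1 to compound 2 (1.15 log units; beyond the scatter), which introduced butylamino in place of dimethylamino. Ethyl(methyl)amino resembles the dimethylamino of compound 1 more than butylamino, so most of that step is expected to reverse in this assay. A higher number is expected, an 8.3-fold higher number from compound 2 to compound 3 (0.92 log units; beyond the scatter). The estimate for compound 3 is 2.5 mg/kg, with an expected range of 0.9 mg/kg to 7 mg/kg.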

Compound 3, dose for half-maximal effect: 0.5 mg/kg
For compound 3 the middle estimate is 5.0-fold (0.70 log units) above the measured one, outside the stated range (below it).
By their numbers in this assay, from the lowest: compounds 2 and 3 (each within the scatter of the next); then compound 1.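

In this assay, one added methyl on the saturated chain carbon accounts for an 8.4-fold lower number from compound 1 to compound 3 (0.92 log units; beyond the scatter) and shows that this position responds to a very small change, without a full butyl chain. Exchanging butylamino for ethyl(methyl)amino gives a 1.7-fold higher number from compound 2 to compound 3 (0.22 log units; within the scatter) and shows that a low number here does not depend on the hydrogen-bond donor of butylamino. Nothing available explains either step.

Still open, from the compounds shown here alone, is whether a longer chain such as hexylamino or a ring amine such as pyrrolidin-1-yl keeps the number as low as for compound 2 and compound 3.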